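Spirooxindole Triazoles Against Breast Cancer Cells: One Limit Throughout

The source may hold more compounds than are shown below. What is called first, only, known or untested is meant among the compounds shown, and "the series" means these compounds.

Measured so far:
Compound 1 `Cc1cccc(-n2nncc2CN2C(=O)C3(C(C#N)=C(N)Oc4c3c3nc5ccccc5nc3c3ccccc43)c3ccccc32)c1`: > 50000 nM
Compound 2 `CCOc1ccccc1-n1nncc1CN1C(=O)C2(C(C#N)=C(N)Oc3c2c2nc4ccccc4nc2c2ccccc32)c2ccccc21`: > 50000 nM
Compound 3 `COc1ccc(-n2nncc2CN2C(=O)C3(C(C#N)=C(N)Oc4c(N)cc5nc6ccccc6nc5c43)c3ccccc32)cc1`: > 50000 nM

All three compounds were tested in a functional assay on MCF7 cells (Homo sapiens) for antiproliferative activity, read by MTT assay, with a stated time of 48 h; a higher number here means a weaker inhibitor, a lower number a stronger inhibitor. Compound 3 gives > 50000 nM there, and this is a limit of the assay rather than a number. Compound 1 and compound 2 likewise sit at a limit, so that the limit of > 50000 nM in this assay, at which 3 of the 3 values shown sit, describes the whole set. For the measured compounds named here, the only pair that differs in one place, compound 1 and compound 2, gives a step that the two limits leave unreadable from compound 1 to compound 2, and nothing about the size of that change can be read from two limits.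

Compound 4 `N#CC1=C(N)Oc2c(N)cc3nc4ccccc4nc3c2C12C(=O)N(Cc1cnnn1-c1cc(Cl)ccc1Cl)c1ccccc12` differs from compound 3 by 2,5-dichlorophenyl in place of 4-methoxyphenyl on an aromatic nitrogen. No measured step bears on this exchange, since the one step shown is itself unreadable. With every value shown at the limit, the step that the limit leaves unreadable from compound 3 to compound 4 is expected to be undetectable, and compound 4 is expected to return a limit again in this assay. The estimate for compound 4 is therefore 80000 nM, between 30000 nM and 300000 nM.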

Compound 4, half-maximal inhibitory concentration: 33200 nM
For compound 4 the middle estimate is 2.4-fold (0.38 log units) above the measured one; measured number inside the range.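

In this assay, for the compounds shown here, compound 4 gives 33200 nM, a number and not a limit, so this exchange on the aromatic nitrogen yields the first step of the set with any readable size. Replacing 4-methoxyphenyl with 2,5-dichlorophenyl gives an at least 1.5-fold lower number from compound 3 to compound 4 (0.17 log units; that floor lies within the scatter), and since that is only a floor within the scatter, it does not yet establish a real difference, though the true step may be larger. The rest of the set stays where it was: the limit of > 50000 nM in this assay, at which 3 of the 4 values shown sit.

As far as these compounds go, whether the two chlorines or the loss of the methoxy group carries the step remains open, as does what an amine or a carboxylic acid on this phenyl ring would give in this assay. Also open, from the compounds shown here alone, is whether 2,5-dichlorophenyl would lift the core of compound 1 clear of the limit.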